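Adding a methyl to the nitrogen of compound 3

The compounds below may be only part of what the source reports. "The series", "measured", "known", "first", "only" and "open" are said of these compounds alone.

In an ADME assay on the whole organism for inhibition, with Echinochloa crus-galli var. formosensis as the target, with a stated time of 4 days (a higher number here means a weaker inhibitor, a lower number a stronger inhibitor), compound 1 `CCCNc1nc(Cl)nc(N[C@@H](C)c2ccccc2)n1` gives 15100 nM, compound 2 `CC(C)N(c1nc(Cl)nc(N[C@@H](C)c2ccccc2)n1)C(C)C` gives 110 nM, and compound 3 `CCCNc1nc(Cl)nc(N[C@H](C)c2ccccc2)n1` gives 33100 nM, the highest number of the three and so the weakest inhibitor. Compound 4 `CCCN(C)c1nc(Cl)nc(N[C@H](C)c2ccccc2)n1` alters compound 3 in one place: methyl in place of hydrogen on a nitrogen on an aromatic ring, turning propylamino into methyl(propyl)amino. Among the measured compounds shown here, the closest precedent is the large step of a 140-fold lower number from compound 1 to compound 2 (2.14 log units; beyond the scatter), which also leaves no hydrogen on that nitrogen, although it starts from the opposite configuration. The modest step of a 2.2-fold higher number from compound 1 to compound 3 (0.34 log units; beyond the scatter) comes down to the fact that compounds 1 and 3 differ only in the configuration as drawn. A smaller change in the same direction is therefore expected, an estimated 11-fold lower number from compound 3 to compound 4 (1.04 log units; beyond the scatter). Compound 4 is expected at 3000 nM, within a range of 300 nM to 20000 nM.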

Compound 4, half-maximal inhibitory concentration: 9770 nM
Compound 4: the middle estimate sits 3.3-fold (0.51 log units) below what was measured, and the stated range covers the measured number.
By their numbers in this assay, from the lowest: compound 2; then compounds 4 and 1 (each within the scatter of the next); then compound 3.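

With the configuration of compound 3 held fixed, one methyl in place of hydrogen on the nitrogen on an aromatic ring is enough to give a 3.4-fold lower number from compound 3 to compound 4 (0.53 log units; beyond the scatter). Among the compounds shown here, until now, a nitrogen without hydrogen had been seen only in compound 2, with diisopropylamino and the opposite configuration. Compound 4 shows that a lower number at this nitrogen also occurs with methyl(propyl)amino and the configuration of compound 3.

Still open, as far as these compounds go, is how an ethyl group in place of that methyl, or the same methyl in compound 1, would read. Nothing shown here explains why the methyl lowers the number.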